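Taking one fluoro off a weakly active compound

This account rests on a few compounds, and the source may have more. Where it says the series, first, only, none or still open, it means among the compounds named here.

In a functional assay on UMUC3 cells (Homo sapiens) for antiproliferative activity, read by MTT assay, with a stated time of 72 h (on this read-out lower numbers stand for stronger inhibition and higher numbers for weaker inhibition), compound 1 (`CC(C)NC(=N)NC(=N)Nc1ccc(C(F)(F)F)cc1`) gives 5200 nM. Compound 2 (`CC(C)NC(=N)NC(=N)Nc1ccc(F)c(F)c1`) gives 25000 nM. That is the higher of the two numbers, so compound 2 is the weaker inhibitor of the pair, by a gap beyond the usual scatter of repeated measurements. These two compounds differ in more than one place, so their gap says little about the effect of any single change.

Compound 3 (`CC(C)NC(=N)NC(=N)Nc1ccc(F)cc1`) comes from compound 2 through one small edit: hydrogen in place of fluoro on an aromatic carbon. Hydrogen stands in place of fluoro on an aromatic carbon, ortho to a fluoro group and meta to a large group. For the measured compounds named here, no measured single-place step is available as a guide, so this expectation is a cautious one. Losing one atom from the ring substituents should change little, with a slight lean towards weaker inhibition. The expected size of a 1.3-fold higher number from compound 2 to compound 3 (0.11 log units; within the scatter) is therefore small and within the scatter. For compound 3 the estimate is 32000 nM, with an expected range from 12000 nM to 80000 nM.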

Compound 3, half-maximal inhibitory concentration: > 50000 nM
Compound 3 gave a limit, no number (the forecaster's own chance of this, stated with the estimate: 15%); at least 1.5-fold (0.19 log units) between middle value and limit.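

In this assay compound 3 gives only a limit, not a number: the limit of > 50000 nM in this assay, at which 1 of the 3 values shown sits.

Hydrogen in place of fluoro on an aromatic carbon gives an at least 2.0-fold higher number from compound 2 to compound 3 (0.30 log units; that floor lies within the scatter), the first step here that changes a single place, and it points towards weaker inhibition, though its floor alone does not clear the usual scatter of repeats. Fluoro in place of trifluoromethyl on an aromatic carbon gives an at least 9.6-fold higher number from compound 1 to compound 3 (0.98 log units; beyond the scatter), and this step does clear the scatter, so the group at that place matters in a way the gap between compound 1 and compound 2, which differ in more than one place, could not show.

As far as these compounds go, what stays open is the true size of both steps, as a limit sets only a floor, so the real cost of losing the fluoro could be small or large. Also open, from the compounds shown here alone, is how other groups on these aromatic carbons, such as chloro, methoxy or an amine, would compare with the fluoro of compound 2 or the trifluoromethyl of compound 1.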